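Working notes: the group on the triple-bonded carbon

The compounds below may be only part of what the source reports. "The series", "measured", "known", "first", "only" and "open" are said of these compounds alone.

In a functional assay on BaF3 cells (Mus musculus) for antiproliferative activity (on this read-out higher numbers stand for an effect only at larger amounts of compound and lower numbers for an effect already at smaller amounts), the measured compounds stand as follows
- compound 1 `CCN1CCN(Cc2ccc(NC(=O)c3ccc(C)c(C#Cc4ccc(NC(=O)C5CC5)nc4)c3)cc2C(F)(F)F)CC1` gives 1800 nM
- compound 2 `CCN1CCN(Cc2ccc(NC(=O)c3ccc(C)c(C#Cc4ccc(C(=O)NC)nc4)c3)cc2C(F)(F)F)CC1` gives 3980 nM
- compound 3 `CCN1CCN(Cc2ccc(NC(=O)c3ccc(C)c(C#Cc4cnc5nccnc5c4)c3)cc2C(F)(F)F)CC1` gives 3320 nM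

Compound 3 at 3320 nM lies within the scatter of both compound 1 and compound 2, and the steps of a 1.8-fold higher number from compound 1 to compound 3 (0.27 log units; within the scatter) and a 1.2-fold lower number from compound 2 to compound 3 (0.08 log units; within the scatter) say so directly. For the measured compounds named here, only the step of a 2.2-fold higher number from compound 1 to compound 2 (0.34 log units; beyond the scatter) passes the scatter, and it is modest.

Compound 4 `CCN1CCN(Cc2ccc(NC(=O)c3ccc(C)c(C#Cc4coc5ccccc45)c3)cc2C(F)(F)F)CC1` keeps the shared core and differs from compound 3 in one place a group of 9 heavy atoms (8 carbon, 1 oxygen; one five-membered aromatic ring with 1 hetero atom, one six-membered aromatic ring of carbon only) in place of a group of 10 heavy atoms (7 carbon, 3 nitrogen; one six-membered aromatic ring with 1 hetero atom, one six-membered aromatic ring with 2 hetero atoms), on a triple-bonded carbon so that 1-benzofuran-3-yl now stands on the triple-bonded carbon. Going by the values given here, all the measured steps alter the group carried on this same carbon, so they are the ones that bear on the change. Even the largest, a 2.2-fold higher number from compound 1 to compound 2 (0.34 log units; beyond the scatter) in size, is modest. Among the compounds with values here, no measured compound carries 1-benzofuran-3-yl, so the direct evidence for this group is missing and the range is kept wide.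

The expected result is a 1.3-fold lower number from compound 3 to compound 4 (0.12 log units; within the scatter) in this assay with no direction expected beyond the scatter. The estimate for compound 4 is 2500 nM with 900 nM to 7000 nM as the expected range.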

Compound 4, half-maximal effective concentration: 6760 nM
Compound 4: middle estimate off by 2.7-fold (0.43 log units), on the low side, and the stated range covers the measured number.
By their numbers in this assay, from the lowest: compounds 1, 3, 2 and 4 (each within the scatter of the next, the first and the last beyond it).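

In this assay, the steps of a 2.0-fold higher number from compound 3 to compound 4 (0.31 log units; beyond the scatter) and a 3.8-fold higher number from compound 1 to compound 4 (0.57 log units; beyond the scatter) pass the scatter, the latter being the largest step yet at this triple-bonded carbon, whereas a 1.7-fold higher number from compound 2 to compound 4 (0.23 log units; within the scatter) does not, so compound 4 cannot be separated from compound 2. Of the four groups on this carbon, 1-benzofuran-3-yl is the only one that has no nitrogen and the only one with a five-membered aromatic ring, and the shared core with this group still gives a measurable antiproliferative effect, though one placed beyond the scatter of compound 1 and compound 3. Nothing measured here accounts for the size of these steps.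

The compounds shown leave open whether the step to compound 4 goes with the loss of nitrogen, with the five-membered ring or with the absence of the amide carried by compound 1 and compound 2, since the groups differ in all of these at once. Also open, going by these compounds, is how a plain phenyl group, or a 1-benzofuran-3-yl bearing an amine or a carboxylic acid, would read on this same carbon.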